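Working notes on the step to compound 3

The compounds below may be only part of what the source reports. "The series", "measured", "known", "first", "only" and "open" are said of these compounds alone.

Measured so far in a physicochemical assay for lipophilicity, read by HPLC, in phosphate buffer, measured as octanol-water partition, at pH 7.4, tested at 100 uM; a higher number here means a more lipophilic compound, a lower number a more polar compound:
- compound 1 `CCCOc1cc(C)c(-c2cccc(CNc3ccc(OCC(=O)O)c(F)c3)c2)c(C)c1` gives 3.59
- compound 2 `O=C(O)COc1ccc(NCc2cccc(-c3ccccc3F)c2)cc1F` gives 2.36

Compound 2 has the lower of the two values, and compound 1 lies above it by a gap beyond the scatter. Compound 3 `Cc1ccc(-c2cccc(CNc3ccc(OCC(=O)O)c(F)c3)c2)c(Cl)c1` differs from compound 2 by one change 2-chloro-4-methylphenyl in place of 2-fluorophenyl on an aromatic carbon with 2-chloro-4-methylphenyl in place of 2-fluorophenyl on an aromatic carbon. For the measured compounds named here, no measured pair yet isolates a single change, so the expectation rests on this structural change alone. The expected move in this assay is upward and beyond the scatter, an estimated step of a number 0.79 log units higher from compound 2 to compound 3 (beyond the scatter) in size. For compound 3 the estimated value is 3.15 with an expected range from 2.8 to 3.5 as its limits.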

Compound 3, distribution coefficient: 3.24
Beside the measured number, compound 3's estimate is 0.09 log units below it, within the range that was stated.
By their numbers in this assay, from the lowest: compound 2; then compound 3; then compound 1.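

In this assay, for the compounds shown here, replacing 2-fluorophenyl with 2-chloro-4-methylphenyl on this aromatic carbon gives the only single-place step, a number 0.88 log units higher from compound 2 to compound 3 (beyond the scatter), so this read-out responds to a change at this position. The step covers the chlorine and the methyl together and cannot be divided between them. Nothing at hand accounts for its size.

The compounds shown leave open what the chlorine or the methyl alone would give at this position. They also leave open how the number would move with an amine or a nitrile on this ring.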